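The source may hold more compounds than are shown below. What is called first, only, known or untested is meant among the compounds shown, and "the series" means these compounds.

Measured in an ADME assay on the whole organism (plasma, strain 129/SvEvBrd x C57BL/6) for pharmacokinetics, with Mus musculus as the target, at a dose of 10 mg/kg by the oral route; a higher number here means more compound in the circulation at the dose given, a lower number less compound in the circulation:
- Compound 1 `CC(=O)c1nc([C@@H](O)[C@H](O)[C@H](O)CO)cn1C`: 10000 ng.h/mL
- Compound 2 `CC(=O)c1nc([C@@H](O)[C@H](O)[C@H](O)CO)c(C)[nH]1`: 2640 ng.h/mL
- Compound 3 `CC(F)(F)c1nc([C@@H](O)[C@H](O)[C@H](O)CO)c[nH]1`: 1190 ng.h/mL

Compound 3 has the lowest number of the three, clearly under compound 2, its nearest neighbour, and further still under compound 1. Compound 4 `OC[C@@H](O)[C@@H](O)[C@H](O)c1c[nH]c(-c2cnccn2)n1` has not yet been measured. It carries pyrazin-2-yl in place of 1,1-difluoroethyl on an aromatic carbon, between two ring nitrogen atoms: pyrazin-2-yl in place of 1,1-difluoroethyl on an aromatic carbon. Within the data shown here, no measured pair here differs in one place only, so this swap has no direct precedent, and compound 3 at 1190 ng.h/mL is the only starting point. The expected change in this assay is none beyond the scatter, with the estimated step of a 1.3-fold higher number from compound 3 to compound 4 (0.10 log units; within the scatter) pointing slightly upward. For compound 4 the expected value is 1500 ng.h/mL, with an estimated range of 450 ng.h/mL to 5000 ng.h/mL.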

Compound 4, area under the concentration-time curve: 1250 ng.h/mL
Compound 4: middle estimate off by 1.2-fold (0.08 log units), on the high side; the range from low to high includes it.
By their numbers in this assay, from the lowest: compounds 3 and 4 (each within the scatter of the next); then compound 2; then compound 1.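

In this assay, pyrazin-2-yl in place of 1,1-difluoroethyl, on the aromatic carbon between two ring nitrogen atoms, gives a 1.1-fold higher number from compound 3 to compound 4 (0.02 log units; within the scatter). This first single-place comparison shows that the position accepts a six-membered aromatic ring with 2 hetero atoms, as well as a small fluorinated chain, with no change beyond the scatter. No supporting measurement bears on this result. As far as these compounds go, whether an amine or a carboxylic acid at this position would give a similar number remains open. So does whether the same swap would hold on the core of compound 2.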